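From a Trifluoromethyl Phenyl Ring to Pyridine

The source may hold more compounds than are shown below. What is called first, only, known or untested is meant among the compounds shown, and "the series" means these compounds.

Of the compounds shown here, three built on one shared core have been tested in a functional assay on KG-1a cells (Homo sapiens) for inhibition, read by MTT assay, with a stated time of 72 h; a higher number here means a weaker inhibitor, a lower number a stronger inhibitor. Compound 1 `Cc1ccc(-n2cc(CCO)nn2)cc1Nc1nccc(-c2cccnc2)n1` gives 6540 nM, and compound 2 `Cc1ccc(-c2nnc(-c3ccc(CN4CCN(C)CC4)c(C(F)(F)F)c3)o2)cc1Nc1nccc(-c2cccnc2)n1` gives 580 nM. Compound 3 `Cc1ccc(-c2nnc(-c3ccc(C)c(C(F)(F)F)c3)o2)cc1Nc1nccc(-c2cccnc2)n1` reaches only the limit of the assay, > 30000 nM, so no exact number is known for it. For the measured compounds named here, the single measured step, an at least 51-fold higher number from compound 2 to compound 3 (1.71 log units; beyond the scatter), shows how far the number rose when the basic side group was removed. Compound 3 thus sits at the limit of > 30000 nM in this assay, at which 1 of the 3 values shown sits.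

Compound 4 `Cc1ccc(-c2nnc(-c3cccnc3)o2)cc1Nc1nccc(-c2cccnc2)n1` differs from compound 3 in one place: pyridin-3-yl in place of 4-methyl-3-(trifluoromethyl)phenyl on an aromatic carbon. Going by the values given here, no measured step touches this part of the structure, so the measured step from compound 2 to compound 3 gives no direct guide here; it only shows that changes away from compound 2 can cost a great deal. The number for compound 1, 6540 nM, shows that the shared core with a small side group can still return a measurable value. A modest move is therefore expected rather than a large one. For compound 4 the expected step from compound 3 is an at least 1.6-fold lower number from compound 3 to compound 4 (0.22 log units; that floor lies within the scatter). Compound 4 is estimated at 18000 nM, with a range from 5000 nM to 60000 nM, and it may well come back as only a limit.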

Compound 4, half-maximal inhibitory concentration: > 30000 nM
Compound 4: a limit, no number (the forecaster's own chance of this, stated with the estimate: 40%); middle value at least 1.6-fold (0.22 log units) away from the limit.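

Compound 3 and compound 4 both end at a limit of the assay rather than at a number, so no step between them can be read: the limit of > 30000 nM in this assay, at which 2 of the 4 values shown sit.

The compounds shown leave open whether pyridin-3-yl in place of 4-methyl-3-(trifluoromethyl)phenyl changes inhibition at all.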